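Vinyl in place of chloromethyl on the amine nitrogen

This account rests on a few compounds, and the source may have more. Where it says the series, first, only, none or still open, it means among the compounds named here.

Within the data shown here, in an assay for inhibition of gamma-butyrobetaine dioxygenase (Homo sapiens), read by HPLC, with stated times of 15 min and 30 min (a higher number here means a weaker inhibitor, a lower number a stronger inhibitor), compound 3 `C[N+](C)(CCl)CCCC(=O)[O-]` gives 268000 nM, the highest of the two numbers measured so far. Its nearest neighbour is compound 2 `CC(C)[N+](C)(C)CCCC(=O)[O-]`, which in this assay gives 5700 nM; the step of a 47-fold higher number from compound 2 to compound 3 (1.67 log units; beyond the scatter). Compound 1 `C[N+](C)(CCCC(=O)[O-])CC1CC1` reaches only the limit > 1000000 nM in this assay, so that value is a limit and not a number. The step of an at least 3.7-fold lower number from compound 1 to compound 3 (0.57 log units; beyond the scatter) and the step of an at least 170-fold lower number from compound 1 to compound 2 (2.24 log units; beyond the scatter) show that exchanges on this amine nitrogen move the numbers strongly in both directions.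

Compound 4 `C=C[N+](C)(C)CCCC(=O)[O-]` differs from compound 3 by vinyl in place of chloromethyl on an amine nitrogen. Among the measured compounds shown here, no measured step swaps chloromethyl for vinyl, so the bearing steps are only indirect: the step of a 47-fold higher number from compound 2 to compound 3 (1.67 log units; beyond the scatter) was large and the step of an at least 3.7-fold lower number from compound 1 to compound 3 (0.57 log units; beyond the scatter) at least modest. A step of moderate size in this assay toward a lower number is expected for compound 4, since groups of similar extent to chloromethyl have not shown the large loss seen for cyclopropylmethyl. The expected step is a 4.5-fold lower number from compound 3 to compound 4 (0.65 log units; beyond the scatter). Compound 4 is estimated at 60000 nM, within 6000 nM to 600000 nM.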

Compound 4, half-maximal inhibitory concentration: 127000 nM
Beside the measured number, compound 4's estimate is 2.1-fold (0.33 log units) below it, within the range that was stated.
By their numbers in this assay, from the lowest: compound 2; then compound 4; then compound 3. At a limit, above all of these: compound 1.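

In this assay, exchanging chloromethyl for vinyl, two groups of equal heavy-atom count on the amine nitrogen, changes the number only modestly: a 2.1-fold lower number from compound 3 to compound 4 (0.32 log units; beyond the scatter). Vinyl stays far from isopropyl, a 22-fold higher number from compound 2 to compound 4 (1.35 log units; beyond the scatter), so among the compounds shown, the large gain at this nitrogen belongs to isopropyl alone, and neither the chlorine-bearing group nor the double-bond group approaches it. The step of an at least 7.8-fold lower number from compound 1 to compound 4 (0.89 log units; beyond the scatter) starts from a limit and not a number, so it stands only as a bound.

On these data alone, whether ethyl or a longer chain such as propyl on the amine nitrogen would fall nearer to isopropyl or to vinyl stays open. Also open, as far as these compounds go, is whether the order of these groups would hold with an amide or an ester in place of the carboxylate.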